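Swapping an Arylamino Group for a Piperidine Ring

The compounds below may be only part of what the source reports. "The series", "measured", "known", "first", "only" and "open" are said of these compounds alone.

Compound 2 `Nc1ccccc1NC(=O)c1ccc(Cn2cnc3c(Nc4cccc(OC(F)(F)F)c4)nc(Cl)nc32)cc1` sits at the bottom of the two numbers gathered so far. In a functional assay on HCT-116 cells (Homo sapiens) for antiproliferative activity, read by CCK-8 assay, with a stated time of 72 h, tested at 2 uM (a higher number here means a stronger effect of the compound at the concentration tested, a lower number a weaker effect), compound 2 gives 1.6%, while compound 1 `Cc1ccc(Nc2nc(Cl)nc3c2ncn3Cc2ccc(C(=O)Nc3ccccc3N)cc2)cc1` gives 76.3%. Among the measured compounds shown here, the only measured step, a number 74.7 percentage points lower from compound 1 to compound 2 (beyond the scatter), exchanges one aromatic ring on the nitrogen for another aromatic ring.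

Compound 3 `CC1CCN(c2nc(Cl)nc3c2ncn3Cc2ccc(C(=O)Nc3ccccc3N)cc2)CC1` is not yet measured. It differs from compound 2 in one place: 4-methylpiperidin-1-yl in place of (3-(trifluoromethoxy)phenyl)amino on an aromatic carbon. This change removes the whole arylamino group and puts a saturated ring in its place, so the step from compound 1 to compound 2, which only swapped one aryl ring for another, does not bear on it directly. What the two measured numbers do show is that a change at this place can move the read-out by a large amount. With no closer guide, the expectation for compound 3 is an intermediate number with a wide spread: the step of a number 23.4 percentage points higher from compound 2 to compound 3 (beyond the scatter) is expected to be a rise, though held with little confidence. Compound 3 is therefore estimated at 25%, with a range from 0% to 75%.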

Compound 3, a percentage reported as inhibition, at one concentration (the size of the read-out at that concentration, not a potency): 70.9%
Estimate against measurement, compound 3: 45.9 percentage points below; the range from low to high includes it.
By their numbers in this assay, from the lowest: compound 2; then compounds 3 and 1 (each within the scatter of the next).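

Within this assay, placing 4-methylpiperidin-1-yl on this aromatic carbon in place of (3-(trifluoromethoxy)phenyl)amino gives a number 69.3 percentage points higher from compound 2 to compound 3 (beyond the scatter). The same saturated ring in place of (4-methylphenyl)amino gives a number 5.4 percentage points lower from compound 1 to compound 3 (within the scatter), so it stands level with that arylamino group in this read-out. The entering group has no aromatic ring and 0 hydrogen-bond donors, so among these three compounds neither feature of the arylamino group is needed for a high number, and the low number belongs to compound 2 alone.

On these data alone, it remains open whether the methyl group on the piperidine ring matters, and how a plain piperidine, a morpholine or a piperazine would read at this place, while a single-concentration read-out cannot separate compound 3 from compound 1 in potency. Nothing available here accounts for why the two arylamino groups differ so widely or why the saturated ring matches one of them.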